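A few compounds are considered here, and "the series" means these few. Any claim that something is new, unique, unknown or untested is made for them only; others in the source may bear on it.

Measured compounds in a functional assay on HCT-116 cells (Homo sapiens) for inhibition, read by MTT assay, with a stated time of 48 h; on this read-out lower numbers stand for stronger inhibition and higher numbers for weaker inhibition:
- compound 1, `COc1cc(NCc2ccc(Br)cc2)cc(OC)c1OC`: > 80000 nM
- compound 2, `C/C=C/C=C/C(=O)N(Cc1ccc(OC)c(O)c1)c1cc(OC)c(OC)c(OC)c1`: 180 nM
- compound 3, `COc1cc(NCc2cccc(O)c2)cc(OC)c1OC`: 67700 nM

The value for compound 1 is a limit of this assay, not a number (the limit of > 80000 nM in this assay, at which 1 of the 3 values shown sits). Compound 2 stands lowest of the two numbers shown; compound 3 sits far above it, and the distance between them lies beyond the scatter. Among the measured compounds shown here, the only step measured between single-point neighbours runs an at least 1.1-fold lower number from compound 1 to compound 3 (0.07 log units; that floor lies within the scatter), and its floor lies within the scatter.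

Compound 4, `COc1ccc(CN(C(=O)C[Se]C#N)c2cc(OC)c(OC)c(OC)c2)cc1O`, is not yet measured. It differs from compound 2 as follows: a group of 4 heavy atoms (2 carbon, 1 nitrogen, 1 selenium; no ring) in place of a group of 5 heavy atoms (5 carbon; no ring), on a carbonyl carbon. For the measured compounds named here, neither measured step touches the carbonyl carbon, so no step here bears on this change; the step from compound 1 to compound 3 concerns a different position in a different series. The expectation therefore rests on compound 2 alone, whose value of 180 nM sets the reference, and on the fact that the shared core of compound 2 is kept intact in compound 4. The estimated step is a 2.2-fold higher number from compound 2 to compound 4 (0.35 log units; beyond the scatter), with wide uncertainty in either direction. Compound 4 is expected to give about 400 nM, within a range of 80 nM to 3000 nM.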

Compound 4, half-maximal inhibitory concentration: 310 nM
Compound 4: middle estimate off by 1.3-fold (0.11 log units), on the high side; the measured number falls inside the stated range.
By their numbers in this assay, from the lowest: compounds 2 and 4 (each within the scatter of the next); then compound 3. At a limit, above all of these: compound 1.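

In this assay, the carbonyl carbon proves able to carry two quite different groups. Replacing the penta-1,3-dien-1-yl group, with its 2 double bonds, by the selenium-bearing group with its nitrile triple bond gives a 1.7-fold higher number from compound 2 to compound 4 (0.24 log units; within the scatter) and so leaves no difference that can be told from the scatter. Until this pair, no measured step had touched this position, so the value of compound 2 stood there alone, and compound 4 now gives a first sign that the activity of this series does not rest on the penta-1,3-dien-1-yl group; no measurement shown bears on why the two groups read alike.

The compounds shown leave open whether the selenium atom itself matters, since a sulfur atom in its place or a plain methyl group on the carbonyl carbon is not among them. Going by these compounds, it also remains open how far this position tolerates other kinds of group, such as an amine, a carboxylic acid or a longer chain.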